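Replacing the side chain of compound 2

This account rests on a few compounds, and the source may have more. Where it says the series, first, only, none or still open, it means among the compounds named here.

In a functional assay on MDA-MB-468 cells (Homo sapiens) for antiproliferative activity, read by MTT assay, with a stated time of 48 h (on this read-out lower numbers stand for stronger inhibition and higher numbers for weaker inhibition), compound 1 `CN(C)CCNc1cc2c(cn1)cc(NC(=O)c1ccc(Cl)cc1)c(=O)n2C` gives 1640 nM and compound 2 `COc1ccc(C(=O)Nc2cc3cnc(NCCN(C)C)cc3n(C)c2=O)cc1` gives 15700 nM. Compound 2 therefore holds the higher of the two numbers, on the weaker side of this short series. Compound 3 `COc1ccc(C(=O)Nc2cc3cnc(N4CCN(C)CC4)cc3n(C)c2=O)cc1` keeps the methoxy of compound 2 and differs at another place: 4-methylpiperazin-1-yl in place of (2-(dimethylamino)ethyl)amino on an aromatic carbon. In words, 4-methylpiperazin-1-yl stands in place of (2-(dimethylamino)ethyl)amino on an aromatic carbon, next to the ring nitrogen.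

Among the compounds with values here, the only measured step, a 9.6-fold higher number from compound 1 to compound 2 (0.98 log units; beyond the scatter), is beyond the scatter but is a methoxy in place of chloro exchange at a different place. It shows that one exchange can move the number in this series, but it gives neither size nor direction for the new change. Within the data shown here, no measured pair varies this side chain. The expectation therefore stays anchored on compound 2 at 15700 nM, with no step beyond the scatter foreseen in this assay and a wide margin on either side.

The expected step is a 1.1-fold lower number from compound 2 to compound 3 (0.05 log units; within the scatter). The estimate for compound 3 is 14000 nM, with an expected range of 4500 nM to 40000 nM.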

Compound 3, half-maximal inhibitory concentration: 12600 nM
Compound 3: middle estimate off by 1.1-fold (0.05 log units), on the high side; measured number inside the range.
By their numbers in this assay, from the lowest: compound 1; then compounds 3 and 2 (each within the scatter of the next).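

In this assay the exchange of (2-(dimethylamino)ethyl)amino for 4-methylpiperazin-1-yl on the aromatic carbon next to the ring nitrogen gives a 1.2-fold lower number from compound 2 to compound 3 (0.10 log units; within the scatter), so compound 2 and compound 3 cannot be told apart on this read-out. This is the only pair shown that varies this position, and with the methoxy amide held fixed, it shows that an open chain with no ring and a six-membered non-aromatic ring with 2 hetero atoms read alike here, even though the hydrogen-bond donor of the chain is absent from the ring. No measurement at hand accounts for this parity between the two side chains.

Going by these compounds, whether the same exchange reads alike on the chloro amide of compound 1 stays open, since the side chain has been compared only on the methoxy amide, where the numbers sit on the weak side of the series. On these data alone, how far this position tolerates other groups also stays open, for example morpholin-4-yl, which has oxygen in place of the methylated ring nitrogen, or a longer chain between the two nitrogens of the (2-(dimethylamino)ethyl)amino group.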